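Diarylurea series: growth inhibition, step to compound 4

The source may report more compounds than this note shows. Statements on the series, on what has been measured and on what is new or still open speak of the compounds shown alone.

Measured compounds:
Compound 1 `COc1cc(Cl)cc(-c2nn(-c3cccc(NC(=O)Nc4ccc(Cl)c(C(F)(F)F)c4)c3)cc2-c2ccncc2)c1` gives 98%
Compound 2 `COc1cc(Cl)cc(-c2nn(-c3cccc(NC(=O)Nc4cc(C(F)(F)F)cc(C(F)(F)F)c4)c3)cc2-c2ccncc2)c1` gives 96%
Compound 3 `COc1cc(Cl)cc(-c2nn(-c3cccc(NC(=O)Nc4ccc(Cl)c(Cl)c4)c3)cc2-c2ccncc2)c1` gives 94%

In a functional assay on T47D cells (Homo sapiens) for inhibition, read by sulforhodamine B assay, with a stated time of 48 h, tested at 0.01 uM (a higher number here means a weaker effect of the compound at the concentration tested, a lower number a stronger effect), compound 3 stands lowest of the three numbers, with compound 2 nearest and compound 1 furthest; both differences lie within the scatter, so the three compounds are indistinguishable on these data. Compound 4 `COc1cc(Cl)cc(-c2nn(-c3cccc(NC(=O)Nc4cccc(C(F)(F)F)c4)c3)cc2-c2ccncc2)c1` is not yet measured. It differs from compound 3 by 3-(trifluoromethyl)phenyl in place of 3,4-dichlorophenyl on an amide-type nitrogen. Within the data shown here, one measured step bears on this change: a number 4 percentage points lower from compound 1 to compound 3 (within the scatter), chloro in place of trifluoromethyl on an aromatic carbon, which lies within the scatter. Compound 2 carries trifluoromethyl groups and gives 96%, in the same range. Among the measured compounds shown here, nothing among the measured compounds points to a change beyond the scatter when trifluoromethyl replaces chloro on this ring. Compound 4 is therefore expected to show a number 2 percentage points higher from compound 3 to compound 4 (within the scatter), a step within the scatter. Compound 4 is estimated at 96%, with a range from 87% to 100%.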

Compound 4, a percentage reported as activity, at one concentration (the size of the read-out at that concentration, not a potency): 97%
Compound 4: middle estimate off by 1 percentage points, on the low side; low and high end bracket the measured number.
By their numbers in this assay, from the lowest: compounds 3, 2, 4 and 1 (each within the scatter of the next).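

In this assay, hydrogen can take the place of either earlier substituent on this aryl group without a readable change: a number 1 percentage points higher from compound 2 to compound 4 (within the scatter) for trifluoromethyl and a number 1 percentage points lower from compound 1 to compound 4 (within the scatter) for chloro. The direct exchange of the whole group on the amide-type nitrogen, 3-(trifluoromethyl)phenyl for 3,4-dichlorophenyl, also stays flat, with a number 3 percentage points higher from compound 3 to compound 4 (within the scatter), so at this single concentration the read-out does not separate the aryl groups shown. No measured information on these compounds accounts for this flat result.

The compounds shown leave open whether a plain phenyl, or a phenyl carrying an amine or a carboxylic acid, would move the number beyond the scatter. On these data alone, it also remains open whether these four compounds would separate at other concentrations.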